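The compounds below may be only part of what the source reports. "The series", "measured", "known", "first", "only" and "open" are said of these compounds alone.

Measured compounds:
Compound 1 `Cc1nc2sc(-c3ccc(C(F)(F)F)cc3)nc2c(=O)[nH]1` — 32%
Compound 2 `Cc1nc2sc(-c3ccc(O)cc3)nc2c(=O)[nH]1` — 15%

Among the measured compounds shown here, in an assay on CHO cells for displacement of a labelled ligand from adenosine receptor A3 (Homo sapiens), read by scintillation counting, with a stated time of 120 min, tested at 1 uM (on this read-out lower numbers stand for less inhibition and higher numbers for more inhibition at the one concentration tested (going by the name of the read-out)), compound 2 stands lowest of the two numbers; the only measured step is a number 17 percentage points lower from compound 1 to compound 2 (beyond the scatter). Compound 3 `Cc1nc2sc(-c3ccc(C(=O)O)cc3)nc2c(=O)[nH]1` differs from compound 2 by carboxy in place of hydroxy on an aromatic carbon. For the measured compounds named here, no measured step covers this change: the one step known swaps trifluoromethyl for hydroxy, not hydroxy for carboxy, so it bears on it only loosely. Starting from the low value of compound 2, a step of no more than the scatter is expected, with the carboxy compound estimated to sit similar or slightly lower. Compound 3 is estimated at 12% (range 0% to 30%), an expected step of a number 3 percentage points lower from compound 2 to compound 3 (within the scatter).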

Compound 3, a percentage reported as inhibition, at one concentration (the size of the read-out at that concentration, not a potency): 1%
Estimate against measurement, compound 3: 11 percentage points above, within the range that was stated.
By their numbers in this assay, from the lowest: compound 3; then compound 2; then compound 1.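

In this assay, carboxy at this position gives a number 14 percentage points lower from compound 2 to compound 3 (beyond the scatter) and a number 31 percentage points lower from compound 1 to compound 3 (beyond the scatter), so compound 3 now marks the low end of the three-member series. Hydroxy and carboxy match in their counts of hydrogen-bond donors and acceptors, so these counts alone do not account for the drop. Nothing on hand bears on the cause of these steps.

Going by these compounds, whether a methyl ester or primary amide in place of carboxy would restore the number remains open. So does the effect of an amine or a halogen on this same aromatic carbon.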